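Amide substituent swap in an indole sulfone series, cytotoxicity outlook

The source may hold more compounds than are shown below. What is called first, only, known or untested is meant among the compounds shown, and "the series" means these compounds.

Measured compounds:
- compound 1 `Cc1cc(C)cc(S(=O)(=O)c2c(C(=O)NCc3ccc4nc(N)[nH]c4c3)[nH]c3ccc(Cl)cc23)c1`: 5890 nM
- compound 2 `Cc1cc(C)cc(S(=O)(=O)c2c(C(=O)NC(C)C(=O)NC(C)c3ccccc3F)[nH]c3ccc(Cl)cc23)c1`: 15200 nM
- compound 3 `Cc1cc(C)cc(S(=O)(=O)c2c(C(=O)NC(C)C(=O)NCCn3c(C)cnc3[N+](=O)[O-])[nH]c3ccc(Cl)cc23)c1`: 16000 nM

In an ADME assay on MT4 cells (Homo sapiens) for cytotoxicity, read by MTT assay (on this read-out higher numbers stand for lower toxicity in this test and lower numbers for higher toxicity in this test), compound 1 gives 5890 nM, the lowest of the three numbers; compound 2 gives 15200 nM and compound 3 gives 16000 nM, both beyond the scatter above compound 1. Compound 4 `Cc1cc(C)cc(S(=O)(=O)c2c(C(=O)Nc3cc(C#N)ccn3)[nH]c3ccc(Cl)cc23)c1` is not yet measured. It differs from compound 1 on the amide-type nitrogen: a group of 8 heavy atoms (6 carbon, 2 nitrogen; one six-membered aromatic ring with 1 hetero atom) in place of a group of 11 heavy atoms (8 carbon, 3 nitrogen; one five-membered aromatic ring with 2 hetero atoms, one six-membered aromatic ring of carbon only), on an amide-type nitrogen.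

Going by the values given here, only one measured step involves a single change, and it also sits on an amide-type nitrogen: a 1.1-fold higher number from compound 2 to compound 3 (0.02 log units; within the scatter). That step is within the scatter, so the one comparable replacement on that nitrogen moved the read-out in this assay hardly at all. The groups in that step and in the change from compound 1 to compound 4 are not alike, and the gap between compound 1 and compounds 2 and 3 shows that changes at this position can shift the number beyond the scatter. Compound 4 is therefore expected to stay near compound 1, with a modest expected shift upward of a 1.4-fold higher number from compound 1 to compound 4 (0.13 log units; within the scatter). The estimate for compound 4 in this assay is 8000 nM, with an expected range from 3000 nM to 25000 nM.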

Compound 4, half-maximal cytotoxic concentration: > 53700 nM
Compound 4 was reported as a limit; the forecaster's own chance of this, stated with the estimate: 20%; middle value at least 6.7-fold (0.82 log units) from the limit.
By their numbers in this assay, from the lowest: compound 1; then compounds 2 and 3 (each within the scatter of the next). At a limit, above all of these: compound 4.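

Putting 4-cyanopyridin-2-yl on the amide-type nitrogen in place of the larger group of compound 1 gives an at least 9.1-fold higher number from compound 1 to compound 4 (0.95 log units; beyond the scatter) in this assay. Among the single changes shown at this nitrogen, this is the only one beyond the scatter, whereas the other, a 1.1-fold higher number from compound 2 to compound 3 (0.02 log units; within the scatter), stays within it, so the read-out in this test does not respond alike to every replacement here. The number for compound 4 is a limit of the assay and not a measured endpoint, so the step gives only a minimum size: the limit of > 53700 nM in this assay, at which 1 of the 4 values shown sits.

The single change from compound 1 to compound 4 alters the ring, the size of the group and the presence of a nitrile all at once, and the compounds shown cannot separate these from one another. As far as these compounds go, it remains open whether a plain pyridin-2-yl group without the nitrile would give a similar read-out in this assay, and whether a carboxylic acid or an amine in place of the nitrile would keep the number at this limit.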